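The compounds below may be only part of what the source reports. "The series", "measured", "known", "first", "only" and "open" are said of these compounds alone.

For the measured compounds named here, compound 3 `O=C(/C=C/c1cccc(OCc2ccccc2)c1)c1ccc(Cl)cc1` gives 43400 nM in a functional assay on DU-145 cells (Homo sapiens) for cytotoxicity, read by MTT assay, with a stated time of 68 h (a higher number here means a weaker inhibitor, a lower number a stronger inhibitor), the second highest of the three numbers measured so far. Compound 1 `O=C(/C=C/c1cccc(OCc2ccccc2)c1)c1ccccc1Br` gives 3000 nM, and compound 2 `COc1ccc(C(=O)/C=C/c2cccc(OCc3ccccc3)c2)cc1` gives 51300 nM. Compound 4 `O=C(/C=C/c1cccc(OCc2ccccc2)c1)c1ccc(O)cc1` has not yet been measured; it differs from compound 3 by hydroxy in place of chloro on an aromatic carbon. The step that bears most directly on this change is a 1.2-fold lower number from compound 2 to compound 3 (0.07 log units; within the scatter), where one group on an aromatic carbon replaced another and the number stayed within the scatter. The large steps of a 17-fold higher number from compound 1 to compound 2 (1.23 log units; beyond the scatter) and a 14-fold higher number from compound 1 to compound 3 (1.16 log units; beyond the scatter) concern a different change. The expected step is therefore small, a 1.1-fold lower number from compound 3 to compound 4 (0.04 log units; within the scatter), in no sure direction. Compound 4 is estimated at 40000 nM, within 15000 nM to 120000 nM.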

Compound 4, half-maximal inhibitory concentration: 6300 nM
Estimate against measurement, compound 4: 6.3-fold (0.80 log units) above; measured number outside the range, below it.
By their numbers in this assay, from the lowest: compound 1; then compound 4; then compounds 3 and 2 (each within the scatter of the next).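

On this aromatic carbon, para to a large group, swapping methoxy for chloro had left the number within the scatter, but hydroxy gives a 6.9-fold lower number from compound 3 to compound 4 (0.84 log units; beyond the scatter) in place of chloro. Removing only the methyl from the oxygen of the methoxy gives an 8.1-fold lower number from compound 2 to compound 4 (0.91 log units; beyond the scatter) here, so the free hydroxy sets compound 4 apart from compounds 2 and 3. Even so, 4-hydroxyphenyl in place of 2-bromophenyl still gives a 2.1-fold higher number from compound 1 to compound 4 (0.32 log units; beyond the scatter) at this point.

No measurement here explains the gain. Going by these compounds, whether an amine or a carboxylic acid on this carbon would match hydroxy remains open.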